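The source may report more compounds than this note shows. Statements on the series, on what has been measured and on what is new or still open speak of the compounds shown alone.

Compound 1 `COc1ccc(OC)c(N2C(=O)CSC2c2cccc(C(=O)NCCCCc3ccccc3)c2)c1`: > 1000 nM
Compound 2 `O=C(NCCCCc1ccccc1)c1cccc(C2SCC(=O)N2c2cccc(-c3c[nH]nn3)c2)c1`: 110 nM

Both compounds were tested in a functional assay on HOS-TE85 cells (Homo sapiens) for inhibition, read by CCK-8 assay, with a stated time of 72 h; on this read-out lower numbers stand for stronger inhibition and higher numbers for weaker inhibition. The entry for compound 1 is a limit of the assay, not a number. Going by the values given here, compound 2 therefore provides the only actual number so far, at 110 nM.

Compound 3 `O=C(NCCCCc1ccccc1)c1cccc(C2SCC(=O)N2c2cccc(F)c2)c1` differs from compound 2 as follows: fluoro in place of 1H-1,2,3-triazol-4-yl on an aromatic carbon. This places fluoro in place of 1H-1,2,3-triazol-4-yl on an aromatic carbon, meta to a large group.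

Among the compounds with values here, only one measured step bears on this change: an at least 9.0-fold lower number from compound 1 to compound 2 (0.95 log units; beyond the scatter). That step also introduced the 1H-1,2,3-triazol-4-yl group, but it replaced a different group from the fluoro of compound 3, so it is only a rough guide. Losing that group is expected to weaken inhibition by a clear margin, and the size of that loss remains uncertain.

The expected change is a 5.5-fold higher number from compound 2 to compound 3 (0.74 log units; beyond the scatter). For compound 3 the estimated value is 600 nM, with an expected range of 170 nM to 2500 nM.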

Compound 3, half-maximal inhibitory concentration: 32.4 nM
The estimate for compound 3 lay 19-fold (1.27 log units) above the measured number, outside the stated range (below it).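

In this assay, the 1H-1,2,3-triazol-4-yl group proves not to be required for strong inhibition at this place on the six-membered aromatic ring: putting fluoro there gives a 3.4-fold lower number from compound 2 to compound 3 (0.53 log units; beyond the scatter). The lone fluoro, with no ring and no hydrogen-bond donor or acceptor, thus does better than the larger group it replaces, and exchanging 2,5-dimethoxyphenyl for 3-fluorophenyl gives an at least 30-fold lower number from compound 1 to compound 3 (1.48 log units; beyond the scatter). The entry for compound 1 is a limit of the assay, not a number: the limit of > 1000 nM in this assay, at which 1 of the 3 values shown sits.

Whether the unsubstituted phenyl ring would read as well as compound 3 remains open, so the compounds shown do not tell whether fluoro itself contributes. As far as these compounds go, how chloro, a nitrile or an amine would compare with fluoro at the same place also remains open.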